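The compounds below may be only part of what the source reports. "The series", "measured", "known", "first", "only" and "open" are said of these compounds alone.

Of the compounds shown here, three built on one shared core have so far been tested in a functional assay on HeLa cells (Homo sapiens) for antiproliferative activity, read by spectrophotometry, with a stated time of 2 days; on this read-out lower numbers stand for stronger inhibition of growth and higher numbers for weaker inhibition of growth. Compound 1 `COc1ccc(Nc2ncc(C(F)(F)F)c(N3Cc4cccc(N(C)S(C)(=O)=O)c4C3)n2)cc1C(F)(F)F` gives 14000 nM in this assay. Compound 2 `CN(c1cccc2c1CN(c1nc(Nc3cc(C(F)(F)F)cc(C(F)(F)F)c3)ncc1C(F)(F)F)C2)S(C)(=O)=O` gives 9200 nM. Compound 3 `Cc1ccc(Nc2ncc(C(F)(F)F)c(N3Cc4cccc(N(C)S(C)(=O)=O)c4C3)n2)c(Cl)c1` gives 10900 nM. These three numbers sit close together: compound 3 lies within the usual scatter of both compound 1 and compound 2, so none of the three can be called stronger or weaker than another. Within the data shown here, the one step between two of them that changes a single place, a 1.3-fold lower number from compound 1 to compound 3 (0.11 log units; within the scatter), is also too small to count as a real difference.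

Compound 4 `CN(c1cccc2c1CN(c1nc(Nc3cc(Cl)cc(C(F)(F)F)c3)ncc1C(F)(F)F)C2)S(C)(=O)=O` has not yet been measured. It differs from compound 3 in one place: 3-chloro-5-(trifluoromethyl)phenyl in place of 2-chloro-4-methylphenyl on a nitrogen on an aromatic ring. Compound 2 carries a related ring on the same nitrogen and gives 9200 nM, a number that agrees with compound 3 within the scatter. Among the measured compounds shown here, the only measured step that bears on this change, a 1.3-fold lower number from compound 1 to compound 3 (0.11 log units; within the scatter), was within the scatter, and compounds 1, 2 and 3 all land in the same range despite three different rings on that nitrogen. The step from compound 3 to compound 4 is therefore expected to be a 1.1-fold lower number from compound 3 to compound 4 (0.04 log units; within the scatter), nothing beyond the scatter. Compound 4 is estimated at 10000 nM in this assay, with a likely range from 5000 nM to 22000 nM.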

Compound 4, concentration for 50% growth inhibition: 4300 nM
Estimate against measurement, compound 4: 2.3-fold (0.37 log units) above; measured number outside the range, below it.
By their numbers in this assay, from the lowest: compound 4; then compounds 2, 3 and 1 (each within the scatter of the next).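

The ring on this nitrogen looked interchangeable while compounds 1, 2 and 3 stayed within the scatter of one another, but the 3-chloro-5-(trifluoromethyl)phenyl ring shows that the choice of ring can change the result in this assay: there is a 2.5-fold lower number from compound 3 to compound 4 (0.40 log units; beyond the scatter) and a 3.3-fold lower number from compound 1 to compound 4 (0.51 log units; beyond the scatter). The closest comparison changes a single group on that ring, chloro in place of trifluoromethyl on an aromatic carbon, and it also passes the scatter, with a 2.1-fold lower number from compound 2 to compound 4 (0.33 log units; beyond the scatter), so one group on the ring is enough to shift the number, and compound 4 is the strongest of the four, though all three steps are modest. No measurement shown here accounts for this difference.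

The compounds shown do not reveal whether the chloro group would give the same step on a ring without trifluoromethyl, or how far the number depends on the two groups occurring together. They also leave open what this assay would show with a nitrile, an amine or a carboxylic acid in place of the chloro group on the ring of compound 4.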